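This account rests on a few compounds, and the source may have more. Where it says the series, first, only, none or still open, it means among the compounds named here.

Measured compounds:
compound 1, `CCOC(=O)/C(=C\c1cccc(OCC(=O)OC)c1)c1nc(-c2ccccc2)c(-c2ccccc2)o1`, 2000 nM
compound 2, `O=C(O)COc1cccc(/C=C(\C(=O)O)c2nc(-c3ccccc3)c(-c3ccccc3)o2)c1`, 20300 nM
compound 3, `C[S+]([O-])C(Cc1cccc(OCC(=O)O)c1)c1nc(-c2ccccc2)c(-c2ccccc2)o1`, 7080 nM

In a functional assay for inhibition, with Homo sapiens as the target (a lower number here means a stronger inhibitor, a higher number a weaker inhibitor), compound 1 gives 2000 nM, compound 2 gives 20300 nM and compound 3 gives 7080 nM. Compound 3 stands second highest of the three numbers; its nearest neighbour is compound 2, whose number is higher by a margin beyond the scatter, and its furthest is compound 1, whose number is lower by a margin beyond the scatter. No two of the measured compounds differ in a single place, so no measured step can be read from these three.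

Compound 4, `C=CCC(Cc1cccc(OCC(=O)O)c1)c1nc(-c2ccccc2)c(-c2ccccc2)o1`, has not yet been measured in this assay. It differs from compound 3 by one change: a group of 3 heavy atoms (3 carbon; no ring) in place of a group of 3 heavy atoms (1 carbon, 1 oxygen, 1 sulfur; no ring), on a saturated chain carbon bound to an aromatic carbon and a saturated chain carbon. Among the compounds with values here, nothing among the measured compounds shows what this exchange does, so the direction of the step is uncertain and only a modest change is expected. Compound 4 is expected to give about 4500 nM in this assay, within a range from 1200 nM to 16000 nM. The expected step is therefore a 1.6-fold lower number from compound 3 to compound 4 (0.20 log units; within the scatter), small and possibly within the usual scatter.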

Compound 4, half-maximal inhibitory concentration: 570 nM
For compound 4 the middle estimate is 7.9-fold (0.90 log units) above the measured one, outside the stated range (below it).
By their numbers in this assay, from the lowest: compound 4; then compound 1; then compound 3; then compound 2.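

In this assay, within the data shown here, placing allyl on the saturated chain carbon bound to an aromatic carbon and a saturated chain carbon, in place of the group of one carbon, one oxygen and one sulfur, gives a 12-fold lower number from compound 3 to compound 4 (1.09 log units; beyond the scatter) and is the only single-place step in this set. It shows that the group at this position can move the number by a large margin beyond the scatter, with the rest of the structure held constant, which compounds 1, 2 and 3 could not show because they differ from one another in more than one place. The exchange removes a hydrogen-bond acceptor and brings in a double bond outside aromatic rings, but nothing measured here ties the step to either difference or explains it.

From the compounds shown here alone, what a saturated propyl chain would do at this carbon stays open, so the part played by the double bond cannot be separated from that of the all-carbon chain. Also open, going by these compounds, is how a shorter ethyl group, a longer butyl chain or an amine at the same position would compare with allyl.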